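The compounds below may be only part of what the source reports. "The series", "measured", "known", "first", "only" and "open" are said of these compounds alone.

Among the two compounds measured in a functional assay on DU-145 cells (Homo sapiens) for cytotoxicity, read by MTT assay (a higher number here means a weaker inhibitor, a lower number a stronger inhibitor), compound 2 `CC(O)(CSc1ccc(Br)cc1)c1nc(-c2ccc([N+](=O)[O-])c(C(F)(F)F)c2)no1` is the only one that returns a number: compound 2 gives 1600 nM. Compound 1 `CC(O)(CS(=O)(=O)c1ccc(Br)cc1)c1nc(-c2ccc([N+](=O)[O-])c(C(F)(F)F)c2)no1` gives > 100000 nM, which is a limit of the assay and not a number (the limit of > 100000 nM in this assay, at which 1 of the 2 values shown sits). Among the compounds with values here, the single measured step, an at least 62-fold lower number from compound 1 to compound 2 (1.79 log units; beyond the scatter), concerns the linker between the chain and the bromophenyl group, not the ring beyond it. Compound 3 `CC(O)(CSc1ccccc1)c1nc(-c2ccc([N+](=O)[O-])c(C(F)(F)F)c2)no1` differs from compound 2 at a different place: hydrogen in place of bromo on an aromatic carbon, para to a large group. Within the data shown here, no measured step touches that bromine, so the measured data give no direct guide to its weight. For compound 3 the expected change in this assay is therefore a 1.6-fold higher number from compound 2 to compound 3 (0.19 log units; within the scatter), a step no larger than the usual scatter. The estimate for compound 3 is 2500 nM, within a range from 600 nM to 10000 nM.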

Compound 3, half-maximal inhibitory concentration: 3000 nM
Compound 3: middle estimate off by 1.2-fold (0.08 log units), on the low side, and the stated range covers the measured number.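

In this assay, hydrogen in place of bromo on the aromatic carbon, para to a large group, gives a 1.9-fold higher number from compound 2 to compound 3 (0.27 log units; within the scatter), so bromo and hydrogen cannot be told apart at this position. The wider step, an at least 33-fold lower number from compound 1 to compound 3 (1.52 log units; beyond the scatter), carries two changes at once, the linker and the bromine, so it cannot be pinned on either one alone. Compound 1 stands at a limit of the assay and not at a number, so that step is only a minimum: the limit of > 100000 nM in this assay, at which 1 of the 3 values shown sits.

From the compounds shown here alone, whether a group such as methoxy or an amine at this position would move the number beyond the scatter remains open. Going by these compounds, it is also open whether the sulfonyl linker would weigh as heavily on the phenyl ring without bromine.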